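Mirror Image of Compound 1 Against the Calcium Flux Assay

A few compounds are considered here, and "the series" means these few. Any claim that something is new, unique, unknown or untested is made for them only; others in the source may bear on it.

Going by the values given here, compound 1 `C[C@@]1(c2ccc(OC(F)(F)F)cc2)C[C@@](O)(c2ccccn2)CO1` is the weakest inhibitor among the three compounds measured so far: in an assay on HEK293 cells for antagonist activity at transient receptor potential cation channel subfamily V member 3 (Homo sapiens), read by FLIPR and calcium flux (a higher number here means a weaker inhibitor, a lower number a stronger inhibitor), compound 1 gives 1120 nM. The two other compounds, built on different cores, sit well below it. Compound 2 `O[C@H](c1ccccn1)[C@]1(c2cccc(C(F)(F)F)c2)C[C@H](O)C1` gives 90 nM in this assay, and compound 3 `O[C@H](c1ccccn1)C1(c2cccc(OC(F)(F)F)c2)CCC1` gives 80 nM in this assay; the gaps from compound 1 to each of these lie beyond the scatter.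

Compound 4 `C[C@]1(c2ccc(OC(F)(F)F)cc2)C[C@](O)(c2ccccn2)CO1` has not yet been measured. It is the mirror image of compound 1 (the two compounds have the same atoms and bonds and differ only in configuration as drawn: 2 of 2 stereo elements differ (all stereocentres are inverted: mirror images); a stereocentre at a saturated ring carbon is drawn S in compound 1 and R in compound 4; a stereocentre at a saturated ring carbon is drawn R in compound 1 and S in compound 4). Among the compounds with values here, no pair of enantiomers has been measured here, so nothing in the data fixes which hand is favoured. Since compound 1 stands well above compounds 2 and 3, the untested hand is estimated to have a fair chance of being the stronger one, though the step could also run the other way. The step from compound 1 to compound 4 in this assay is expected to be a 3.2-fold lower number from compound 1 to compound 4 (0.51 log units; beyond the scatter), with wide uncertainty in direction. Compound 4 is estimated at 350 nM in this assay, within a range of 40 nM to 3000 nM.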

Compound 4, antagonist equilibrium constant: 420 nM
Compound 4: middle estimate off by 1.2-fold (0.08 log units), on the low side; the range from low to high includes it.
By their numbers in this assay, from the lowest: compounds 3 and 2 (each within the scatter of the next); then compound 4; then compound 1.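

In this assay, inverting both stereocentres gives a 2.7-fold lower number from compound 1 to compound 4 (0.43 log units; beyond the scatter), so this core shows a real but modest preference for one hand, with compound 4 as the favoured form. Going by these compounds alone, this is the first pair in the set in which configuration alone changes, whereas the earlier compounds differ from one another in more than one place and could say nothing about handedness. The gap can be assigned to handedness alone because of one fact: the fact that compounds 1 and 4 differ only in the configuration as drawn.

Both stereocentres invert together in this pair, and the compounds shown do not tell whether one of them alone carries the preference. They also leave open whether the same hand is favoured when a nitrile or a carboxylic acid takes the place of the trifluoromethoxy group.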